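Alkyne series: trifluoromethoxy to hydroxy at the aryl oxygen

A few compounds are considered here, and "the series" means these few. Any claim that something is new, unique, unknown or untested is made for them only; others in the source may bear on it.

Measured in a functional assay on CHO cells for agonist activity at metabotropic glutamate receptor 5 (Homo sapiens), read by inositol phosphate accumulation; a higher number here means a weaker inhibitor, a lower number a stronger inhibitor:
compound 1, `Cc1nc(C#Cc2cccc(F)c2)cs1`, gives 23 nM
compound 2, `COc1cccc(C#Cc2csc(C)n2)c1`, gives 49 nM
compound 3, `Cc1nc(C#Cc2cccc(OC(F)(F)F)c2)cs1`, gives 266 nM

Compound 3 stands highest of the three numbers: a 12-fold higher number from compound 1 to compound 3 (1.06 log units; beyond the scatter) and a 5.4-fold higher number from compound 2 to compound 3 (0.73 log units; beyond the scatter). Compound 4, `Cc1nc(C#Cc2cccc(O)c2)cs1`, differs from compound 3 by hydrogen in place of trifluoromethyl on an oxygen on an aromatic ring.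

Among the measured compounds shown here, two measured steps bear on this change. For the measured compounds named here, the step of a 5.4-fold higher number from compound 2 to compound 3 (0.73 log units; beyond the scatter) is the one that alters the group on that same oxygen, and it raised the number; the step of a 2.1-fold higher number from compound 1 to compound 2 (0.33 log units; beyond the scatter) shows that the methoxy compound itself already sits somewhat above the fluoro compound. Taking the trifluoromethyl off the oxygen entirely is expected to undo most of the rise seen in a 5.4-fold higher number from compound 2 to compound 3 (0.73 log units; beyond the scatter), so a step of a 4.4-fold lower number from compound 3 to compound 4 (0.65 log units; beyond the scatter) toward a lower number is expected for compound 4. Going by the values given here, no measured compound carries a hydroxy, so how hydroxy compares with methoxy is not known from these data, and the range is kept wide.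

For compound 4 the expected value in this assay is 60 nM, with a range of 20 nM to 180 nM.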

Compound 4, half-maximal inhibitory concentration: 654 nM
Compound 4: middle estimate off by 11-fold (1.04 log units), on the low side; the whole stated range lies below it.
By their numbers in this assay, from the lowest: compound 1; then compound 2; then compound 3; then compound 4.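

In this assay, a free hydroxy does not bring the number back down: the step of a 2.5-fold higher number from compound 3 to compound 4 (0.39 log units; beyond the scatter) shows that removing trifluoromethyl from this oxygen raises it further, so methyl gives the lowest number of the three groups on the oxygen, with trifluoromethyl above it and hydrogen highest. The number therefore does not move in one direction from hydrogen through methyl to trifluoromethyl, and the loss on going from methyl to hydrogen is large, with a 13-fold higher number from compound 2 to compound 4 (1.13 log units; beyond the scatter) as its measure. Hydroxy also falls far behind fluoro on the aromatic carbon, seen in a 28-fold higher number from compound 1 to compound 4 (1.45 log units; beyond the scatter), making compound 4 the weakest of the four, and nothing available accounts for this.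

As far as these compounds go, whether an ethyl on this oxygen would stay close to methyl remains open. So does whether an amine in place of the hydroxy would sit nearer to compound 1 or to compound 4.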